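The source may hold more compounds than are shown below. What is called first, only, known or untested is meant among the compounds shown, and "the series" means these compounds.

Series notes, cytotoxicity. Compound 1 `CCCCCCCCCCCCCCNC(=O)[C@H](CO)/N=C/c1ccc(O)cc1` gives 71700 nM in an ADME assay on HEK293 cells (Homo sapiens) for cytotoxicity; a higher number here means a weaker inhibitor, a lower number a stronger inhibitor. Compound 2 `CCCCCCCCCCCCCCNC(=O)[C@H](CO)/N=C/c1ccccc1C` gives 81100 nM in this assay. The step of a 1.1-fold higher number from compound 1 to compound 2 (0.05 log units; within the scatter) shows that the two aryl groups on the carbon with a double bond to nitrogen are indistinguishable on these numbers. Compound 2 holds the highest of the two numbers, with compound 1 nearest at a step within the scatter, so no order between the two is established.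

Compound 3 `CCCCCCCCCCCCCCNC(=O)[C@H](CO)/N=C/c1cccc(OC)c1` differs from compound 2 in one place: 3-methoxyphenyl in place of 2-methylphenyl on a carbon with a double bond to nitrogen. Within the data shown here, the only measured step that bears on this change is the one from compound 1 to compound 2, which was within the scatter. Among the measured compounds shown here, no step with a methoxy group on this ring has been measured, so nothing beyond the scatter is expected in this assay. Compound 3 is therefore expected to give 78000 nM (range 40000 nM to 150000 nM), an estimated step of a 1.0-fold lower number from compound 2 to compound 3 (0.02 log units; within the scatter).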

Compound 3, half-maximal inhibitory concentration: 77300 nM
Estimate against measurement, compound 3: 1.0-fold (0.00 log units) above; the measured number falls inside the stated range.
By their numbers in this assay, from the lowest: compounds 1, 3 and 2 (each within the scatter of the next).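

The 3-methoxyphenyl group on the carbon with a double bond to nitrogen is not separated from 2-methylphenyl (a 1.0-fold lower number from compound 2 to compound 3 (0.02 log units; within the scatter)) or from 4-hydroxyphenyl (a 1.1-fold higher number from compound 1 to compound 3 (0.03 log units; within the scatter)) in this assay on these numbers. With the three aryl groups all within the scatter of each other, compound 1, compound 2 and compound 3 have no established order, and the entry of a hydrogen-bond acceptor on this aryl group from compound 2 to compound 3 brings no readable change. No measurement is at hand that bears on the reason for this result.

On these data alone, it stays open whether an amine or a carboxylic acid on this ring would give a step beyond the scatter. The same holds for a shorter or longer chain in place of the long chain of the shared core.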